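A few compounds are considered here, and "the series" means these few. Any claim that something is new, unique, unknown or untested is made for them only; others in the source may bear on it.

Three compounds share one core and differ only in the group that sits on an aromatic carbon of a six-membered aromatic ring of carbon only, para to a large group. Compound 1 `CCC(C)(C)Cc1c[nH]c(CCc2ccc(-c3ccncc3)cc2)n1` carries a pyridin-4-yl group there, and in a functional assay on HEK293 cells for agonist activity at Bombesin receptor subtype-3 (Homo sapiens), read by luminescence and calcium flux, with a stated time of 10 min (a lower number here means that less compound is needed, a higher number that more compound is needed for the effect), compound 1 gives 95 nM. Compound 2 `CCC(C)(C)Cc1c[nH]c(CCc2ccc(-n3ncnn3)cc2)n1` carries a 2H-tetrazol-2-yl group, and in this assay compound 2 gives 89 nM. Compound 3 `CCC(C)(C)Cc1c[nH]c(CCc2ccc(-c3cccc(C#N)n3)cc2)n1` carries a 6-cyanopyridin-2-yl group, and in this assay compound 3 gives 95 nM. Compound 3 thus sits alongside the other two: the steps of a 1.1-fold lower number from compound 1 to compound 2 (0.03 log units; within the scatter), no change at the digits printed from compound 1 to compound 3 (within the scatter) and a 1.1-fold higher number from compound 2 to compound 3 (0.03 log units; within the scatter) all stay within the scatter, so the three aromatic groups tried so far cannot be told apart on these numbers.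

Compound 4 `CCC(C)(C)Cc1c[nH]c(CCc2ccc(-c3ccccc3C(=O)O)cc2)n1` takes the next step: 2-carboxyphenyl in place of 6-cyanopyridin-2-yl on an aromatic carbon. The three measured steps bear on it, since each also swapped one aromatic group for another at this same carbon without moving the number beyond the scatter. None of those groups, however, brought a hydrogen-bond donor, so the present change goes further than any step already seen. The expectation for compound 4 is therefore a modest step, a 1.6-fold higher number from compound 3 to compound 4 (0.20 log units; within the scatter), in this assay. Compound 4 is estimated at 150 nM, within a range from 40 nM to 600 nM.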

Compound 4, half-maximal effective concentration: 101 nM
For compound 4 the middle estimate is 1.5-fold (0.17 log units) above the measured one; low and high end bracket the measured number.
By their numbers in this assay, from the lowest: compounds 2, 1, 3 and 4 (each within the scatter of the next).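

In this assay the change to 2-carboxyphenyl gives a 1.1-fold higher number from compound 3 to compound 4 (0.03 log units; within the scatter) even though this group brings a hydrogen-bond donor, which none of the earlier groups had, and replaces a ring with a hetero atom by a six-membered aromatic ring of carbon only. The other two comparisons read the same way, with a 1.1-fold higher number from compound 2 to compound 4 (0.05 log units; within the scatter) and a 1.1-fold higher number from compound 1 to compound 4 (0.03 log units; within the scatter), so the four groups on this aromatic carbon cannot be told apart on these numbers, and the presence of a hydrogen-bond donor in the group makes no visible difference here. No outside measurement is available to explain why the numbers stay so close.

From the compounds shown here alone, all four groups are aromatic rings, so it remains open whether a group without a ring on this carbon, such as a simple amine or a short alkyl chain, would keep the number in the same range. Also open, going by these compounds, is what a methyl ester in place of the carboxylic acid of compound 4 would give, and whether any group at this carbon can move the number beyond the scatter at all.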